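The compounds below may be only part of what the source reports. "The series", "measured", "known", "first", "only" and "open" are said of these compounds alone.

Compound 1 `CCc1cc(=O)c2ccc(OC)c(CBr)c2o1`: in a functional assay on KB cells (Homo sapiens) for antiproliferative activity, read by sulforhodamine B assay, with a stated time of 72 h (a higher number here means a weaker inhibitor of growth, a lower number a stronger inhibitor of growth), compound 1 gives > 33600 nM, which is a limit of the assay.
Compound 2 `CCOc1ccc2c(=O)cc(CC)oc2c1CBr`: in this assay compound 2 gives > 32100 nM, again a limit.
Compound 3 `CCc1cc(=O)c2ccc(OC(C)C)c(CBr)c2o1`: in this assay compound 3 gives > 30700 nM, also a limit.

Compound 3 therefore stands at no fixed number, only at a limit, and the same holds for the other two compounds: the limit of > 30700 nM in this assay, at which 1 of the 3 values shown sits, the limit of > 32100 nM in this assay, at which 1 of the 3 values shown sits, and the limit of > 33600 nM in this assay, at which 1 of the 3 values shown sits, together cover every value shown. Each measured step is unreadable: a step that the two limits leave unreadable from compound 1 to compound 2, a step that the two limits leave unreadable from compound 1 to compound 3 and a step that the two limits leave unreadable from compound 2 to compound 3. None of them tells in which direction, or by how much, the shared core answers to a change on the oxygen on the aromatic ring.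

Compound 4 `CCc1cc(=O)c2ccc(OCC(C)C)c(CBr)c2o1` carries the next change in that same place: isobutyl in place of isopropyl on an oxygen on an aromatic ring. The step from isopropyl to isobutyl adds one carbon to the chain on that oxygen, a change of the same kind as the ones already measured. Since every comparable step ended at a limit, a further limit is the most likely outcome, and the step that the limit leaves unreadable from compound 3 to compound 4 is expected to be small or not readable at all. Compound 4 is estimated at 33000 nM in this assay, within a range from 10000 nM to 100000 nM.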

Compound 4, concentration for 50% growth inhibition: > 29400 nM
Compound 4: only a limit was reported; the forecaster's own chance of this, stated with the estimate: 85%; the middle value lies beyond the limit too.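

Compound 4 also stops at a limit of the assay, so its steps from compound 1, compound 2 and compound 3 cannot be read, in either size or direction. The compounds shown leave open at what concentration any of the four inhibits growth in this assay, and whether the chain on the oxygen on the aromatic ring matters at all.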